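This account rests on a few compounds, and the source may have more. Where it says the series, first, only, none or still open, it means among the compounds named here.

Working notes on the series.

Compound 1 `c1ccc(COc2ccccc2Nc2ncnc3cc4c(cc23)OCCOCCO4)cc1` and compound 2 `c1ccc(COc2ccccc2Nc2ncnc3cc4c(cc23)OCCOCCOCCO4)cc1` carry cores whose difference is not broken down here. In a functional assay on SH-SY5Y cells (Homo sapiens) for antiproliferative activity, read by MTT assay, with a stated time of 72 h (on this read-out higher numbers stand for weaker inhibition and lower numbers for stronger inhibition), compound 1 gives 93700 nM. In this assay compound 2 gives 98400 nM, a number that sits within the usual scatter of the value for compound 1, so the two are not separated.

Compound 3 `FC(F)(F)c1ccc(COc2ccccc2Nc2ncnc3cc4c(cc23)OCCOCCOCCO4)cc1` is obtained from compound 2 by trifluoromethyl in place of hydrogen on an aromatic carbon. In this assay compound 3 reaches only > 100000 nM, which is a limit of the assay and not a number; this is the point described by the limit of > 100000 nM in this assay, at which 1 of the 3 values shown sits. The step of an at least 1.0-fold higher number from compound 2 to compound 3 (0.00 log units; that floor lies within the scatter) is therefore only a floor, and that floor lies within the scatter.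

Compound 4 `FC(F)(F)c1ccc(COc2ccccc2Nc2ncnc3cc4c(cc23)OCCOCCO4)cc1` is not yet measured. It stands to compound 1 as compound 3 stands to compound 2: trifluoromethyl in place of hydrogen on an aromatic carbon, the same change, at the same place in the same words. Resting on the floor seen for compound 3 > 100000 nM, compound 4 is expected to move by about a 1.1-fold higher number from compound 1 to compound 4 (0.05 log units; within the scatter), which would again likely meet the limit. In this assay compound 4 is estimated at 105000 nM, between 60000 nM and 200000 nM.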

Compound 4, half-maximal inhibitory concentration: > 100000 nM
Compound 4 was reported as a limit (the forecaster's own chance of this, stated with the estimate: 60%); the middle value does not contradict the limit.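

On the core of compound 1, trifluoromethyl in place of hydrogen on an aromatic carbon gives an at least 1.0-fold higher number from compound 1 to compound 4 (0.02 log units; that floor lies within the scatter) in this assay, and this step is only a floor.

What carries from one core to the other is that compound 3 and compound 4 both end at a limit of the assay and not at a number: the limit of > 100000 nM in this assay, at which 2 of the 4 values shown sit.

What this does not show is whether the change has the same size on the two cores, or any size beyond the scatter on either one: the same change on two cores in this assay, an at least 1.0-fold higher number (0.00 log units; that floor lies within the scatter) from compound 2 to compound 3 and an at least 1.0-fold higher number (0.02 log units; that floor lies within the scatter) from compound 1 to compound 4; the limit leaves it open whether they differ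

The compounds shown leave open whether another group in the same place on the benzyl ring, such as an amine or a carboxylic acid, would give a number clearly lower than that of compound 1 at 93700 nM. They also leave open whether a longer chain in place of benzyloxy would separate the two cores in this assay, where the values shown all lie close to the limit.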